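Permeability notes on an aryl change in the series

The source may report more compounds than this note shows. Statements on the series, on what has been measured and on what is new or still open speak of the compounds shown alone.

Measured compounds:
- compound 1 `Cc1oc(-c2ccccc2Cl)nc1CN1CCC(C(=O)NCCCN2C[C@H](C)C[C@H](C)C2)CC1`: 352 10^-6 cm/s
- compound 2 `Cc1cccc(Cl)c1-c1nc(CN2CCC(C(=O)NCCCN3CCC(C(C)C)CC3)CC2)c(C)o1`: "not determined" (no result reported)

Within the data shown here, in a physicochemical assay for permeability, using PAMPA (a higher number here means that the compound crosses the layer faster, a lower number that the compound crosses the layer more slowly), compound 1 gives 352 10^-6 cm/s, the only number in hand for the series; compound 2 has no result in this assay, so compound 1 stands alone and no measured step exists to calibrate against.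

Compound 3 `COc1ccc(-c2nc(CN3CCC(C(=O)NCCCN4C[C@H](C)C[C@H](C)C4)CC3)c(C)o2)cc1OC` differs from compound 1 in one place: 3,4-dimethoxyphenyl in place of 2-chlorophenyl on an aromatic carbon. The shared core, the piperidine amide chain and the dimethylpiperidine end are unchanged.

Among the measured compounds shown here, with no measured pair to lean on, the expectation for compound 3 rests on the change alone. A modest step downward from compound 1 is expected, likely near the edge of the usual scatter, so compound 3 is estimated at 200 10^-6 cm/s in this assay, with a range of 90 10^-6 cm/s to 450 10^-6 cm/s. That estimate corresponds to an expected step of a 1.8-fold lower number from compound 1 to compound 3 (0.25 log units; within the scatter).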

Compound 3, apparent permeability: 81.9 10^-6 cm/s
Compound 3: middle estimate off by 2.4-fold (0.39 log units), on the high side; the whole stated range lies above it.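

In this assay, the series now has its first measured step, a 4.3-fold lower number from compound 1 to compound 3 (0.63 log units; beyond the scatter), which lies beyond the usual scatter and shows that this position, on an aromatic carbon of the five-membered aromatic ring, responds to the change from 2-chlorophenyl to 3,4-dimethoxyphenyl. The entering group has 10 heavy atoms and 2 hydrogen-bond acceptors, against 7 heavy atoms and 0 hydrogen-bond acceptors in the group that leaves, while the rest of the structure stays the same. No measurement in hand bears on the reason for this step.

The single step removes the chlorine and adds two methoxy groups at once, so the compounds shown leave open how much each part contributes. Also open, as far as these compounds go, is where a plain phenyl or a 4-methoxyphenyl at this position would fall relative to compound 1 and compound 3.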